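The source may hold more compounds than are shown below. What is called first, only, known or untested is meant among the compounds shown, and "the series" means these compounds.

Measured compounds in a functional assay on MGC-803 cells (Homo sapiens) for inhibition, read by MTT assay, with a stated time of 72 h; on this read-out higher numbers stand for weaker inhibition and lower numbers for stronger inhibition:
compound 1 `O=C(CSc1nc(Nc2ccccc2)c2ccccc2n1)Nc1ccccc1Cl` gives 24800 nM
compound 2 `O=C(CSc1nc(Nc2ccccc2)c2ccccc2n1)Nc1cccc(Cl)c1` gives 14300 nM
compound 3 `O=C(CSc1nc(Nc2ccccc2)c2ccccc2n1)Nc1cccc(Br)c1` gives 9620 nM

Compound 3 stands at the lowest of the three numbers; its gap to compound 2 is within the scatter, whereas the step of a 2.6-fold lower number from compound 1 to compound 3 (0.41 log units; beyond the scatter) lies beyond it. Compound 4 `O=C(CSc1nc(Nc2ccccc2)c2ccccc2n1)Nc1cccc([N+](=O)[O-])c1` differs from compound 3 by nitro in place of bromo on an aromatic carbon. Within the data shown here, no measured step exchanges a halogen for nitro. Among the measured compounds shown here, the nearest precedent is a 1.5-fold lower number from compound 2 to compound 3 (0.17 log units; within the scatter), a swap of one substituent for another on the same aromatic carbon, which stayed within the scatter; the step of a 1.7-fold lower number from compound 1 to compound 2 (0.24 log units; within the scatter) also stayed within it. For the measured compounds named here, on this basis the expected step in this assay is a 1.0-fold higher number from compound 3 to compound 4 (0.02 log units; within the scatter), none beyond the scatter, with a wide range since the entering group has no precedent here. Compound 4 is therefore estimated at 10000 nM (range 4000 nM to 25000 nM).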

Compound 4, half-maximal inhibitory concentration: 28100 nM
Beside the measured number, compound 4's estimate is 2.8-fold (0.45 log units) below it, outside the stated range (above it).
By their numbers in this assay, from the lowest: compounds 3, 2, 1 and 4 (each within the scatter of the next, the first and the last beyond it).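

Among these compounds, on the aromatic carbon carrying bromo in compound 3, nitro gives the first exchange of substituent on that carbon to pass the scatter in this assay (a 2.9-fold higher number from compound 3 to compound 4 (0.47 log units; beyond the scatter)). The same exchange from chloro stays within the scatter (a 2.0-fold higher number from compound 2 to compound 4 (0.29 log units; within the scatter)), and the 3-nitrophenyl compound also stays within it against the 2-chlorophenyl compound (a 1.1-fold higher number from compound 1 to compound 4 (0.05 log units; within the scatter)). No supporting evidence bears on this result. From the compounds shown here alone, whether an amine, a carboxylic acid or a methoxy group on this carbon would track with bromo or with nitro stays open.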